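The source may report more compounds than this note shows. Statements on the series, on what has been measured and on what is new or still open speak of the compounds shown alone.

Working notes on the series. Two compounds carry the shared core with a piperidine and a substituted phenyl on the same carbon. Compound 1, `Oc1ccc2[nH]ncc2c1C(c1ccc(F)cc1)N1CCCCC1`, gives 350 nM in an assay for inhibition of protein disulfide-isomerase (Homo sapiens), with a stated time of 1 h; on this read-out higher numbers stand for weaker inhibition and lower numbers for stronger inhibition. Compound 2, `O=[N+]([O-])c1ccc(C(c2c(O)ccc3[nH]ncc23)N2CCCCC2)cc1`, gives 520 nM in this assay. Going by the values given here, the only step so far, a 1.5-fold higher number from compound 1 to compound 2 (0.17 log units; within the scatter), is the exchange of one substituent on that phenyl for another. Compound 2 thus holds the higher of the two numbers, but its gap to compound 1 does not exceed the scatter, so no order between them can be stated.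

Compound 3, `Oc1ccc2[nH]ncc2c1C(c1ccc(-c2cncnc2)cc1)N1CCCCC1`, is the unmeasured member. Its change from compound 2 is pyrimidin-5-yl in place of nitro on an aromatic carbon, at the same position that was exchanged in the step from compound 1 to compound 2, para to a large group. Among the compounds with values here, no measured step covers a ring entering at that position; the one step that bears on it, a 1.5-fold higher number from compound 1 to compound 2 (0.17 log units; within the scatter), was small. The expectation for compound 3 in this assay is therefore a step of a 1.2-fold lower number from compound 2 to compound 3 (0.06 log units; within the scatter), that is, no shift beyond the scatter. Compound 3 is estimated at 450 nM, with a range of 150 nM to 1500 nM.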

Compound 3, half-maximal inhibitory concentration: 830 nM
Beside the measured number, compound 3's estimate is 1.8-fold (0.27 log units) below it; low and high end bracket the measured number.
By their numbers in this assay, from the lowest: compounds 1, 2 and 3 (each within the scatter of the next, the first and the last beyond it).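

At the aromatic carbon para to a large group, a whole six-membered aromatic ring with hetero atoms can take the place of nitro, with a 1.6-fold higher number from compound 2 to compound 3 (0.20 log units; within the scatter), so this exchange gives no shift beyond the scatter in this assay. Going by these compounds alone, measured against fluoro, the same ring gives a 2.4-fold higher number from compound 1 to compound 3 (0.38 log units; beyond the scatter), the first step at this position to pass the scatter, so the position is not wholly indifferent to what it carries, although the step remains modest. Nothing available on these compounds bears on the reason for this step.

The compounds shown leave open how a plain phenyl ring, with no ring nitrogen, or a carboxylic acid at this position would read in this assay, so the contribution of the ring itself cannot yet be separated from that of its nitrogen atoms. They also leave open whether the steps seen here would hold with a morpholine in place of the piperidine, which is common to all three compounds.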